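Chloro on the pendant phenyl of the methylated core

The source may report more compounds than this note shows. Statements on the series, on what has been measured and on what is new or still open speak of the compounds shown alone.

Two compounds of this series carry a measured value. Compound 1 `N#Cc1c(-c2ccc(Cl)cc2)nc(SCC(=O)Nn2c(COc3ccc(Cl)cc3Cl)nc3ccccc3c2=O)[nH]c1=O` gives 64.9% in a functional assay on the whole organism (strain albino) for inhibition, with Rattus norvegicus as the target, read by paw edema, with stated times of 1 h and 2 h, at a dose of 100 mg/kg by the oral route; on this read-out lower numbers stand for less inhibition and higher numbers for more inhibition at the one dose given (going by the name of the read-out). Compound 2 `Cn1c(SCC(=O)Nn2c(COc3ccc(Cl)cc3Cl)nc3ccccc3c2=O)nc(-c2ccccc2)c(C#N)c1=O` gives 59.7% in this assay, the lower of the two numbers, though the gap to compound 1 lies within the scatter, so no order between them can be read. Compound 3 `Cn1c(SCC(=O)Nn2c(COc3ccc(Cl)cc3Cl)nc3ccccc3c2=O)nc(-c2ccc(Cl)cc2)c(C#N)c1=O` is not yet measured; it differs from compound 2 by chloro in place of hydrogen on an aromatic carbon. Compound 1 already carries the 4-chlorophenyl, and because its 64.9% sits close to compound 2, only a small step in this assay is expected, if any beyond the scatter. For compound 3 the estimate is 63%, with a range from 52% to 74%. The step this estimate means, a number 3.3 percentage points higher from compound 2 to compound 3 (within the scatter), is expected to stay within the scatter.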

Compound 3, a percentage reported as inhibition, in the whole organism at one dose (the size of the read-out at that dose, not a potency): 73.7%
Compound 3: the middle estimate sits 10.7 percentage points below what was measured; the measured number falls inside the stated range.
By their numbers in this assay, from the lowest: compounds 2, 1 and 3 (each within the scatter of the next, the first and the last beyond it).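

For the compounds shown here, on the methylated core, the change from phenyl to 4-chlorophenyl gives in this assay a number 14 percentage points higher from compound 2 to compound 3 (beyond the scatter) as the first step that clears the scatter. With the 4-chlorophenyl kept, methyl in place of hydrogen on the aromatic nitrogen gives a number 8.8 percentage points higher from compound 1 to compound 3 (within the scatter) and so cannot be read as a gain or a loss. Nothing available accounts for the chloro step.

As far as these compounds go, whether fluoro, bromo, methoxy or an amine at the same place would match chloro stays open. So does whether the step holds on the core of compound 1.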